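This account rests on a few compounds, and the source may have more. Where it says the series, first, only, none or still open, it means among the compounds named here.

Of the compounds shown here, three of one shared core have been tested in a functional assay on the whole organism (strain albino) for inhibition, with Rattus norvegicus as the target, read by paw edema, with stated times of 30 min and 5 h, at a dose of 100 mg/kg by the oral route; a higher number here means more inhibition at the dose given (going by the name of the read-out), a lower number less inhibition. Compound 1 `O=C(CBr)Nc1ccc(C(=O)/C=C/c2ccc(Cl)cc2)cc1` gives 54%. Compound 2 `O=C(CO[N+](=O)[O-])Nc1ccc(C(=O)/C=C/c2ccc(Cl)cc2)cc1`, which differs from it only at the saturated chain carbon bound to the carbonyl carbon, gives 60%; the step of a number 6 percentage points higher from compound 1 to compound 2 (within the scatter). Compound 3 `O=C(CO[N+](=O)[O-])Nc1ccc(C(=O)/C=C/c2ccco2)cc1` gives 39%, and the step of a number 21 percentage points lower from compound 2 to compound 3 (beyond the scatter). Of the three numbers, that of compound 2 is the largest, but only its gap to compound 3 is beyond the scatter; compound 1 cannot be told apart from it.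

Compound 4 `CC(=O)c1ccc(OCC(=O)Nc2ccc(C(=O)/C=C/c3ccc(Cl)cc3)cc2)cc1` has not yet been measured. It differs from compound 2 in one place: 4-acetylphenyl in place of nitro on an oxygen on a saturated carbon. Among the compounds with values here, the only measured step that touches this same place is the one from bromo to nitrooxy, and that step stayed within the scatter. The step from compound 2 to compound 3 changed a different part of the molecule and therefore says little about this exchange. Within the data shown here, no measured compound carries a group as large as 4-acetylphenyl at this oxygen, so the expectation rests on thin ground.

Given that, the expected step of a number 3 percentage points lower from compound 2 to compound 4 (within the scatter) is none beyond the scatter. Compound 4 is estimated to give 57%, with a range from 42% to 72%.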

Compound 4, a percentage reported as inhibition, in the whole organism at one dose (the size of the read-out at that dose, not a potency): 55%
Beside the measured number, compound 4's estimate is 2 percentage points above it; low and high end bracket the measured number.
By their numbers in this assay, from the lowest: compound 3; then compounds 1, 4 and 2 (each within the scatter of the next).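

In this assay, placing 4-acetylphenyl in place of nitro on the oxygen on a saturated carbon gives a number 5 percentage points lower from compound 2 to compound 4 (within the scatter), and the wider exchange of bromo for 4-acetylphenoxy gives a number 1 percentage points higher from compound 1 to compound 4 (within the scatter). The numbers for bromo, nitrooxy and 4-acetylphenoxy at this place therefore cannot be told apart in these three compounds with the 4-chlorophenyl group, even though 4-acetylphenyl brings 9 heavy atoms and a six-membered aromatic ring where nitro has 3 heavy atoms and no ring; the nitrooxy group is thus not required to reach this level of inhibition at the single dose tested. Nothing measured here gives a reason for this result.

From the compounds shown here alone, it remains open whether 4-acetylphenoxy would also match nitrooxy with furan-2-yl in place of 4-chlorophenyl, the change that took compound 2 to compound 3 with a step beyond the scatter. Also open, going by these compounds, is how this place would respond to an amine, a carboxylic acid or a longer chain, and whether a plain phenoxy group would give a similar number.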